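From Dipropylamino to Pyrrolidin-1-yl on a Shared Core

The compounds below may be only part of what the source reports. "The series", "measured", "known", "first", "only" and "open" are said of these compounds alone.

Compound 1, `COc1ccc(NC2=CC(=O)c3nc4n(c3C2=O)[C@H]2OC[C@@H](O)[C@H]2OC4)cc1`, gives 5420 nM in a functional assay on MCF7 cells (Homo sapiens) for inhibition, read by sulforhodamine B assay; on this read-out higher numbers stand for weaker inhibition and lower numbers for stronger inhibition.
Compound 2, `CCCN(CCC)C1=CC(=O)c2nc3n(c2C1=O)[C@H]1OC[C@@H](O)[C@H]1OC3`, gives only > 16000 nM in this assay, which is a limit of the assay and not a number.

Compound 2 therefore stands at the weak end of the two values shown, sitting at the limit of > 16000 nM in this assay, at which 1 of the 2 values shown sits. Compound 3, `O=C1C=C(N2CCCC2)C(=O)c2c1nc1n2[C@H]2OC[C@@H](O)[C@H]2OC1`, differs from compound 2 by pyrrolidin-1-yl in place of dipropylamino on a double-bonded ring carbon. Among the compounds with values here, the one measured step, an at least 2.9-fold higher number from compound 1 to compound 2 (0.47 log units; beyond the scatter), concerns a different exchange, so it does not fix the size of this one. Compound 3 is expected to stay near the limit, at 13000 nM, within 4500 nM to 40000 nM. That estimate implies an at least 1.2-fold lower number from compound 2 to compound 3 (0.09 log units; that floor lies within the scatter).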

Compound 3, half-maximal inhibitory concentration: > 16000 nM
Compound 3: no number, only a limit (the forecaster's own chance of this, stated with the estimate: 50%); middle value at least 1.2-fold (0.09 log units) away from the limit.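

The step between compound 2 and compound 3 cannot be read, as each carries only a limit of the assay and not a number: the limit of > 16000 nM in this assay, at which 2 of the 3 values shown sit. Closing the open dipropylamino chains into pyrrolidin-1-yl therefore brings no readable gain in inhibition. Placing pyrrolidin-1-yl where (4-methoxyphenyl)amino stood gives an at least 2.9-fold higher number from compound 1 to compound 3 (0.47 log units; beyond the scatter), so only the (4-methoxyphenyl)amino group yields a readable number here.

Which part of that group matters remains open. Phenylamino or cyclohexylamino on the same double-bonded ring carbon could begin to separate the methoxy group from the aromatic ring.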